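The source may report more compounds than this note shows. Statements on the series, on what has been measured and on what is new or still open speak of the compounds shown alone.

Measured compounds:
compound 1, `O=C(NC1CCN(Cc2ccn(-c3ccc(C(F)(F)F)cc3)c2)CC1)N1CCn2cccc2C1c1ccccc1`: 10 nM
compound 2, `O=C(NC1CCN(Cc2ccn(-c3ccc(C(F)(F)F)cc3)c2)CC1)N1CCCC(CO)C1`: 23 nM
compound 3, `CN1CCN(C(=O)NC2CCN(Cc3ccn(-c4ccc(C(F)(F)F)cc4)c3)CC2)C(c2ccccc2)C1`: 28 nM

Three compounds share a core and were tested in an assay on HEK293 cells for displacement of a labelled ligand from melanin-concentrating hormone receptor 1 (Homo sapiens); on this read-out higher numbers stand for weaker inhibition and lower numbers for stronger inhibition. Compound 2 gives the second highest of the three numbers in this assay. Its nearest neighbour is compound 3, whose number lies only slightly higher, within the usual scatter of the measurement, so the two cannot be told apart. Compound 1 is the furthest, with a number that lies lower than that of compound 2 by a margin beyond the scatter.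

Compound 4, `O=C(NC1CCN(Cc2ccn(-c3ccc(C(F)(F)F)cc3)c2)CC1)N1CCCCC1CCO`, has not yet been measured. It differs from compound 2 in one place: 2-(2-hydroxyethyl)piperidin-1-yl in place of 3-(hydroxymethyl)piperidin-1-yl on a carbonyl carbon. For the measured compounds named here, no pair of measured compounds shows what such a rearrangement of the hydroxy-bearing piperidine does in this assay, so the size of the step must be guessed from the spread of the three numbers already seen. The step of a 1.1-fold higher number from compound 2 to compound 4 (0.04 log units; within the scatter) is expected to stay within the scatter, with no clear direction. Compound 4 is therefore estimated to give 25 nM in this assay, within a range from 9 nM to 70 nM.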

Compound 4, half-maximal inhibitory concentration: 39 nM
Compound 4: middle estimate off by 1.6-fold (0.19 log units), on the low side; low and high end bracket the measured number.
By their numbers in this assay, from the lowest: compound 1; then compounds 2, 3 and 4 (each within the scatter of the next).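

In this assay, 2-(2-hydroxyethyl)piperidin-1-yl in place of 3-(hydroxymethyl)piperidin-1-yl on a carbonyl carbon gives a 1.7-fold higher number from compound 2 to compound 4 (0.23 log units; within the scatter), the first step read at this position. This pair therefore shows that the change leaves the number within the scatter, even though the entering group has one more heavy atom and the hydroxy group sits at a different place on the six-membered ring. Both the place on the ring and the chain length change in this single step, so the pair cannot say what either change does alone, and nothing measured alongside these compounds accounts for the size of the step.

Going by these compounds, a 2-(hydroxymethyl)piperidin-1-yl or a 3-(2-hydroxyethyl)piperidin-1-yl group on the same carbonyl carbon would pull the two changes apart, and that question stays open. Also open, on these data alone, is what the hydroxy group itself contributes, which an unsubstituted piperidin-1-yl, a methoxy, an amine or a carboxylic acid at the end of the chain would address, and how a longer chain such as 3-hydroxypropyl would read in this assay.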